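The source may hold more compounds than are shown below. What is called first, only, known or untested is meant among the compounds shown, and "the series" means these compounds.

Compound 2 `CCOC(=O)C1CCN(CCCOc2cc3ncnc(Nc4ccc(C#N)cc4)c3cc2OC)CC1` is one of two compounds with a number in a functional assay on A549 cells (Homo sapiens) for antiproliferative activity, read by MTT assay, with a stated time of 72 h; a higher number here means a weaker inhibitor, a lower number a stronger inhibitor. In this assay compound 2 gives 89900 nM. Its only companion, compound 1 `COc1cc2c(Nc3ccc(C#N)cc3)ncnc2cc1OCCCN(C)C`, gives 60500 nM in this assay, and the step of a 1.5-fold higher number from compound 1 to compound 2 (0.17 log units; within the scatter) leaves the two within the scatter of each other, so neither can be called the weaker inhibitor. That step exchanged one amine group for another on the same saturated chain carbon, three bonds along the chain from an oxygen on an aromatic ring.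

Compound 3 `COc1cc2c(Nc3ccc(C#N)cc3)ncnc2cc1OCCCN1CCc2ccccc2C1` has not yet been measured. It differs from compound 2 in exactly that place: 1,2,3,4-tetrahydroisoquinolin-2-yl in place of 4-(ethoxycarbonyl)piperidin-1-yl on a saturated chain carbon, three bonds along the chain from an oxygen on an aromatic ring. Going by the values given here, the single measured step that bears on this change is the one between compound 1 and compound 2, which also swapped the group on that chain carbon and stayed within the scatter. No other information about this position exists. The expectation for compound 3 is therefore a step of a 1.2-fold lower number from compound 2 to compound 3 (0.08 log units; within the scatter), that is, nothing beyond the scatter in either direction. The value expected for compound 3 in this assay is 75000 nM, with a range from 30000 nM to 200000 nM.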

Compound 3, half-maximal inhibitory concentration: > 100000 nM
Compound 3 ended at the assay's limit; the forecaster's own chance of this, stated with the estimate: 10%; middle value at least 1.3-fold (0.12 log units) away from the limit.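

In this assay compound 3 gives > 100000 nM, which is a limit of the assay and not a number: the limit of > 100000 nM in this assay, at which 1 of the 3 values shown sits.

Against its two companions, the result gives an at least 1.1-fold higher number from compound 2 to compound 3 (0.04 log units; that floor lies within the scatter) and an at least 1.6-fold higher number from compound 1 to compound 3 (0.21 log units; that floor lies within the scatter), so neither comparison shows a change beyond the scatter, yet neither places compound 3 level with its companion, as only a floor is known. What it adds is a third amine group at this place, and the first to carry a six-membered aromatic ring of carbon only, and even with this group none of the three compounds reaches a low number in this assay.

Going by these compounds, how far compound 3 really lies from compound 1 and compound 2 stays open, as does whether the aromatic ring in 1,2,3,4-tetrahydroisoquinolin-2-yl matters at all. Also open, on these data alone, is whether any other change on this chain, such as morpholin-4-yl as the amine, a carboxylic acid in place of the ethyl ester of compound 2, or a longer chain, would bring the number down.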